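This account rests on a few compounds, and the source may have more. Where it says the series, first, only, none or still open, it means among the compounds named here.

Compound 1 `Cc1ccc(Cc2ncn3c(S)ncnc23)cc1` and compound 2 `CN(C)c1ncnc2c(Cc3ccccc3)ncn12` share the same core and differ in both side groups. In a functional assay on CCRF-CEM cells (Homo sapiens) for cytotoxicity (on this read-out higher numbers stand for lower toxicity in this test and lower numbers for higher toxicity in this test), compound 1 gives 32800 nM. For compound 2 this assay reports only a limit, > 790000 nM. Compound 2 thus sits at the limit of > 790000 nM in this assay, at which 1 of the 2 values shown sits. Compound 3 `Cc1ccc(Cc2ncn3c(N(C)C)ncnc23)cc1` stands apart from compound 2 by methyl in place of hydrogen on an aromatic carbon. Among the compounds with values here, no measured step of this kind is at hand, so compound 3 is expected to stay close to compound 2, with a step that the limit leaves unreadable from compound 2 to compound 3 amounting to no shift beyond the scatter. Compound 3 is estimated at 800000 nM, between 200000 nM and 3000000 nM, and will most likely again be reported only as a limit.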

Compound 3, half-maximal cytotoxic concentration: 412000 nM
The estimate for compound 3 lay 1.9-fold (0.29 log units) above the measured number, within the range that was stated.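

In this assay, methyl in place of hydrogen on the aromatic carbon para to a large group gives an at least 1.9-fold lower number from compound 2 to compound 3 (0.28 log units; that floor lies within the scatter), so this change is not shown to move the read-out beyond the scatter. Compound 2 has only a limit, which leaves the true size of this step unknown: the limit of > 790000 nM in this assay, at which 1 of the 3 values shown sits. The change at the other place, dimethylamino in place of sulfanyl on an aromatic carbon, gives a 13-fold higher number from compound 1 to compound 3 (1.10 log units; beyond the scatter), a large step that can be read in full.

The compounds shown leave open how a primary amine, a carboxylic acid or a longer chain would fare in place of dimethylamino. They also leave open whether chloro or methoxy in place of the methyl would change the read-out.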